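Fluoro for methyl on the pendant phenyl of compound 2

The source may hold more compounds than are shown below. What is called first, only, known or untested is meant among the compounds shown, and "the series" means these compounds.

Within the data shown here, compound 2 `CCOC(=O)c1c(C)[nH]c(=O)c(C#N)c1-c1ccc(C)cc1` is the one member of the series with a number in a functional assay on A549 cells (Homo sapiens) for inhibition, read by MTT assay, with a stated time of 24 h; on this read-out lower numbers stand for stronger inhibition and higher numbers for weaker inhibition: compound 2 gives 15900 nM. Compound 1 `CCOC(=O)c1c(C)[nH]c(=O)c(C#N)c1-c1ccccc1` returns only a limit in this assay, > 100000 nM. Compound 3 `CCOC(=O)c1c(C)[nH]c(=O)c(C#N)c1-c1ccc([N+](=O)[O-])cc1` likewise returns only a limit, > 100000 nM. The measured steps therefore read as an at least 6.2-fold lower number from compound 1 to compound 2 (0.79 log units; beyond the scatter) and an at least 6.2-fold higher number from compound 2 to compound 3 (0.79 log units; beyond the scatter), while a step that the two limits leave unreadable from compound 1 to compound 3. Both limits are the same one, (the limit of > 100000 nM in this assay, at which 2 of the 3 values shown sit).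

Compound 4 `CCOC(=O)c1c(C)[nH]c(=O)c(C#N)c1-c1ccc(F)cc1` differs from compound 2 in one place: fluoro in place of methyl on an aromatic carbon. Among the measured compounds shown here, no measured step introduces fluoro, so the bearing of the measured steps is indirect: hydrogen and nitro at this position each gave a limit, and methyl alone gave a number. For the measured compounds named here, a fluoro substituent is a third group at the same aromatic carbon, with no precedent. On this basis compound 4 is expected to give a higher number than compound 2 in this assay, with a step estimated at a 2.8-fold higher number from compound 2 to compound 4 (0.45 log units; beyond the scatter), and a fair chance that only a limit is reported. The estimate for compound 4 is 45000 nM, within a range from 15000 nM to 150000 nM.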

Compound 4, half-maximal inhibitory concentration: 15400 nM
Compound 4: middle estimate off by 2.9-fold (0.47 log units), on the high side; measured number inside the range.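

In this assay, replacing methyl with fluoro gives a 1.0-fold lower number from compound 2 to compound 4 (0.01 log units; within the scatter), so a measurable number at this aromatic carbon no longer belongs to methyl alone. Fluoro stands apart from hydrogen and from nitro just as methyl does, with an at least 6.4-fold lower number from compound 1 to compound 4 (0.81 log units; beyond the scatter) and an at least 6.4-fold lower number from compound 3 to compound 4 (0.81 log units; beyond the scatter). Those two steps give bounds and not sizes, because each starts from a limit and not from a number: the limit of > 100000 nM in this assay, at which 2 of the 4 values shown sit.

With two groups giving numbers and two giving limits, the series supports no rule for what this carbon accepts, and the step between hydrogen and nitro cannot be read; chloro, methoxy or an amine at the same place would show whether the level shared by compound 2 and compound 4 extends to other groups. As far as these compounds go, all four compounds also share the rest of the core, so it stays open whether a change elsewhere, such as a carboxylic acid in place of the ethyl ester, would keep this level with methyl and fluoro alike.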